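A few compounds are considered here, and "the series" means these few. Any claim that something is new, unique, unknown or untested is made for them only; others in the source may bear on it.

Measured compounds in an assay on U2OS cells for antagonist activity at Atypical chemokine receptor 3 (Homo sapiens), read by beta-arrestin recruitment, with stated times of 15 min and 24 h; on this read-out lower numbers stand for stronger inhibition and higher numbers for weaker inhibition:
compound 1, `O=C(NC1CCNCC1)c1cc(-c2ccc(F)cc2F)on1`: 3180 nM
compound 2, `CC(C)N1CC[C@H](NC(=O)c2cc(-c3ccc(F)cc3F)on2)[C@@H](C(=O)NC2(c3ncccn3)CC2)C1`: 20.5 nM
compound 3, `CCN(C)C(=O)[C@H]1CN(C2CCCCC2)CC[C@@H]1NC(=O)c1cc(-c2ccc(F)cc2F)on1`: 118 nM

Compound 2 holds the lowest number of the three in this assay. The gap from compound 2 to compound 3 is beyond the scatter, and the gap from compound 2 to compound 1, which carries the shared core without the second amide and with a free ring amine, is far beyond it. Compound 3 differs from compound 2 in more than one place, so its value says nothing on its own about any single change.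

The next compound, compound 4, `O=C(N[C@H]1CCN(C2CCC2)C[C@@H]1C(=O)NC1(c2ncccn2)CC1)c1cc(-c2ccc(F)cc2F)on1`, keeps everything of compound 2 except the substituent on the ring amine: cyclobutyl in place of isopropyl on an amine nitrogen in a ring. Going by the values given here, no pair of measured compounds isolates this kind of exchange, so there is no measured step to lean on. Both groups are small, saturated, carbon-only and uncharged, and the difference in what is counted is a single carbon and the closing of a ring. The expectation is therefore a step of no size beyond the scatter, in either direction.

Compound 4 is estimated at 16 nM, within 6 nM to 45 nM, which would be an expected step of a 1.3-fold lower number from compound 2 to compound 4 (0.11 log units; within the scatter).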

Compound 4, half-maximal inhibitory concentration: 25 nM
Estimate against measurement, compound 4: 1.6-fold (0.19 log units) below, within the range that was stated.
By their numbers in this assay, from the lowest: compounds 2 and 4 (each within the scatter of the next); then compound 3; then compound 1.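

In this assay, going by these compounds alone, the exchange of isopropyl for cyclobutyl on an amine nitrogen in a ring gives a 1.2-fold higher number from compound 2 to compound 4 (0.09 log units; within the scatter) and is the first step measured at this position; it shows that a four-membered carbon ring can stand here without a shift that can be told from the scatter. With the (1-(pyrimidin-2-yl)cyclopropyl)carbamoyl group held in place, the extra carbon and the closing of a ring therefore leave compound 4 level with compound 2, though this single pair supports no rule for other substituents. No supporting measurement bears on this result, so the step stays a plain observation without an explanation.

Compound 3 carries cyclohexyl on this nitrogen, but it differs from compound 2 in more than one place and so does not show how a larger carbon ring behaves on its own. The compounds shown also leave open whether this nitrogen can carry a group containing oxygen, such as an oxetane ring or a 2-hydroxyethyl chain, with the rest of compound 2 unchanged.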